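Solubility notes on a shared-core series: three measured, one pending

The source may hold more compounds than are shown below. What is called first, only, known or untested is meant among the compounds shown, and "the series" means these compounds.

Measured compounds in a physicochemical assay for solubility, with a stated time of 18 h, at pH 7.4; a lower number here means a less soluble compound, a higher number a more soluble compound:
- compound 1 `COc1ccc(F)cc1CNCCCNc1ccnc2cc(Cc3ccc(C#N)cc3)ccc12`: 4200 nM
- compound 2 `COc1ccc(-c2ccc3c(NCCCNCc4cccc(OC)c4O)ccnc3c2)cc1`: 32000 nM
- compound 3 `FC(F)(F)c1ccc(-c2ccc3c(NCCCNCc4ccco4)ccnc3c2)cc1`: 32000 nM

Compound 3 stands level with compound 2 at the digits shown, the two together giving the highest numbers of the three; compound 1 sits well below both, and that gap lies beyond the scatter. Among the compounds with values here, no pair of measured compounds differs in one place only, so no single step is available as a guide.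

Compound 4 `c1ccc(-c2ccc3c(NCCCNCc4ccco4)ccnc3c2)cc1` is the next compound to be measured. It differs from compound 3 by hydrogen in place of trifluoromethyl on an aromatic carbon of a six-membered aromatic ring of carbon only.

Within the data shown here, nothing among the measured compounds isolates this change. Compound 4 is expected to give a step of a 1.4-fold higher number from compound 3 to compound 4 (0.15 log units; within the scatter), a modest move toward a higher number, close to the scatter. Compound 4 is estimated at 45000 nM, with a range of 16000 nM to 100000 nM in this assay.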

Compound 4, solubility: 32000 nM
For compound 4 the middle estimate is 1.4-fold (0.15 log units) above the measured one; measured number inside the range.
By their numbers in this assay, from the lowest: compound 1; then compounds 2, 3 and 4 (each within the scatter of the next).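

In this assay, within the data shown here, hydrogen in place of trifluoromethyl gives no change at the digits printed from compound 3 to compound 4 (within the scatter), the first comparison that isolates a single place. On this aromatic carbon, para to a large group, the loss of the trifluoromethyl therefore leaves the read-out unmoved within the scatter, at least with the side chain shared by these two compounds. No measurement at hand bears on why this step is flat.

On these data alone, whether an amine or a carboxylic acid on this carbon would read the same remains open. So does whether the same change reads alike with another side chain on the shared core.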